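Hydroxy addition on the cinnamate series: expected lipophilicity shift

The source may hold more compounds than are shown below. What is called first, only, known or untested is meant among the compounds shown, and "the series" means these compounds.

Measured so far:
compound 1, `C/C1=C\[C@@H]2[C@H](CC[C@@]3(C)O[C@@H]3[C@H]3[C@@H](O)[C@@H](CO)C[C@]3(OC(=O)/C=C/c3ccccc3)C1=O)C2(C)C`, 4.8
compound 2, `C/C1=C\[C@@H]2[C@H](CC[C@@]3(C)O[C@@H]3[C@H]3[C@@H](O)[C@@H](COC(=O)c4ccccc4)C[C@]3(OC(=O)/C=C/c3ccccc3)C1=O)C2(C)C`, 7.2

In a physicochemical assay for lipophilicity (on this read-out lower numbers stand for lower lipophilicity and higher numbers for higher lipophilicity), compound 2 stands highest of the two numbers; its nearest neighbour is compound 1, reached by a number 2.40 log units higher from compound 1 to compound 2 (beyond the scatter).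

Compound 3, `CC1(C)[C@@H]2/C=C(\CO)C(=O)[C@@]3(OC(=O)/C=C/c4ccccc4)C[C@H](COC(=O)c4ccccc4)[C@H](O)[C@@H]3[C@H]3O[C@]3(C)CC[C@@H]21`, is not yet measured. It differs from compound 2 by hydroxy in place of hydrogen on a saturated chain carbon bound to a double-bonded ring carbon. Among the measured compounds shown here, the only measured step in this assay, a number 2.40 log units higher from compound 1 to compound 2 (beyond the scatter), concerns benzoyl in place of hydrogen on an oxygen on a saturated carbon and so does not mirror the present change; no measured pair shows a hydroxy entering in place of hydrogen. For the measured compounds named here, with no direct precedent, a moderate downward step is expected, a number 1.00 log units lower from compound 2 to compound 3 (beyond the scatter), leaving compound 3 between compound 1 and compound 2. For compound 3 the estimated value in this assay is 6.2, with a range from 5.4 to 7.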

Compound 3, partition coefficient: 5.9
The estimate for compound 3 lay 0.30 log units above the measured number; the measured number falls inside the stated range.
By their numbers in this assay, from the lowest: compound 1; then compound 3; then compound 2.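

In this assay, hydroxy in place of hydrogen on a saturated chain carbon bound to a double-bonded ring carbon, the change from methyl to hydroxymethyl, gives a number 1.30 log units lower from compound 2 to compound 3 (beyond the scatter). Among the compounds shown here, this is the first measured change at this position, and it shows that the read-out responds to a single hydroxy entering here, with the benzoyl ester of compound 2 retained in compound 3. Nothing available accounts for the size of this step.

On these data alone, whether the step would carry over to the core of compound 1, which lacks the benzoyl, remains open. Also open, as far as these compounds go, is how an amine, a carboxylic acid or a longer chain at this position would compare with the hydroxy of compound 3.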